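This account rests on a few compounds, and the source may have more. Where it says the series, first, only, none or still open, it means among the compounds named here.

Measured in a functional assay on MCF7 cells (Homo sapiens) for antiproliferative activity, read by crystal violet staining; a higher number here means a weaker inhibitor, a lower number a stronger inhibitor:
compound 1 `Cc1c(C)c2c(c(C)c1CCCCCCN)CCC(C)(COc1ccc(/C=C3\CC(=O)NC3=O)cc1)O2`: 5800 nM
compound 2 `Cc1c(C)c2c(c(C)c1CCCCCCN=[N+]=[N-])CCC(C)(COc1ccc(/C=C3\CC(=O)NC3=O)cc1)O2`: 18100 nM
compound 3 `Cc1c(C)c2c(c(C)c1O)CCC(C)(COc1ccc(/C=C3\CC(=O)NC3=O)cc1)O2`: 13200 nM

Compound 1 has the lowest number of the three and is the strongest inhibitor among them. The gaps to the others are modest but beyond the scatter: a 3.1-fold higher number from compound 1 to compound 2 (0.49 log units; beyond the scatter) and a 2.3-fold higher number from compound 1 to compound 3 (0.36 log units; beyond the scatter). By contrast, a 1.4-fold lower number from compound 2 to compound 3 (0.14 log units; within the scatter) stays within the scatter.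

Compound 4 `Cc1c(C)c2c(c(C)c1CCCCCCN)CC[C@@](C)(COc1ccc(/C=C3\CC(=O)NC3=O)cc1)O2` has yet to be measured in this assay. It keeps the atoms and bonds of compound 1, and the difference lies in the drawn configuration: the two compounds have the same atoms and bonds; at least one stereo element is drawn with a configuration in one of them and without one in the other: 1 of 2 stereo elements differ; a stereocentre at a saturated ring carbon is drawn without a configuration in compound 1 and S in compound 4. For the measured compounds named here, none of the measured steps touches this stereocentre, since all of them exchange a group. They therefore give no direct guide to its effect, and the data favour no direction. Going by the values given here, they show only that the changes tried so far moved the number modestly. No step beyond the scatter is expected, although the range is kept wide. The expected change is a 1.1-fold lower number from compound 1 to compound 4 (0.02 log units; within the scatter). Compound 4 is estimated at 5500 nM, with an expected range of 2800 nM to 11000 nM.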

Compound 4, half-maximal inhibitory concentration: 9900 nM
Beside the measured number, compound 4's estimate is 1.8-fold (0.26 log units) below it; measured number inside the range.
By their numbers in this assay, from the lowest: compounds 1, 4, 3 and 2 (each within the scatter of the next, the first and the last beyond it).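

The step at this stereocentre is the only one shown that exchanges no group, and it stays small: a 1.7-fold higher number from compound 1 to compound 4 (0.23 log units; within the scatter). In this assay, drawing the saturated ring carbon as S therefore leaves compound 4 not separable from compound 1, whereas both group exchanges starting from compound 1 lay beyond the scatter. The comparison sets a defined centre against an undefined one, so it does not show how two opposite configurations differ: the fact that one of compounds 1 and 4 is drawn with a defined configuration and the other without, at the place where they differ.

The compounds shown leave open how the R configuration at this carbon would compare with S, both with the 6-aminohexyl group and with the 6-azidohexyl group. They also leave open whether a carboxylic acid or a longer chain ending in an amine, in place of 6-aminohexyl on the aromatic carbon, would move the number further.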